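Methoxy in Place of Methyl on a Fused Ring

This account rests on a few compounds, and the source may have more. Where it says the series, first, only, none or still open, it means among the compounds named here.

Of the compounds shown here, two have been tested in a functional assay on the whole organism with Rattus norvegicus as the target, read by paw edema, with a stated time of 3 h, at a dose of 100 mg/kg by the oral route; a lower number here means less inhibition, a higher number more inhibition at the dose given (going by the name of the read-out). Compound 1 `COc1ccc2[nH]c(-c3cccc(C)n3)nc2c1` gives 40% in this assay. Compound 2 `CCc1cccc(-c2nc3cc(C)ccc3[nH]2)n1` gives 10%, the lower of the two numbers, standing below compound 1 by a gap beyond the usual scatter. The two compounds differ in two places at once, so no single structural step can be read off between them.

Compound 3 `CCc1cccc(-c2nc3cc(OC)ccc3[nH]2)n1` has not yet been measured. Against compound 2 the change is methoxy in place of methyl on an aromatic carbon. Among the measured compounds shown here, no step of this kind has been measured here, so its size is unknown. Because compound 1 carries a methoxy group and gives 40%, a rise from compound 2 is a reasonable expectation, though compound 1 also differs elsewhere. The step of a number 15 percentage points higher from compound 2 to compound 3 (beyond the scatter) is therefore expected to be upward but modest. Compound 3 is estimated at 25%, within a range of 5% to 50%.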

Compound 3, a percentage reported as inhibition, in the whole organism at one dose (the size of the read-out at that dose, not a potency): 52%
The estimate for compound 3 lay 27 percentage points below the measured number; measured number outside the range, above it.
By their numbers in this assay, from the lowest: compound 2; then compound 1; then compound 3.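

In this assay, among the compounds shown here, replacing methyl with methoxy on this aromatic carbon of the fused two-ring system gives a number 42 percentage points higher from compound 2 to compound 3 (beyond the scatter), the first single-place reading of this change, and it shows that this position strongly affects the result in this pair. The other single change, methyl in place of hydrogen on the saturated chain carbon bound to an aromatic carbon, gives a number 12 percentage points higher from compound 1 to compound 3 (beyond the scatter), so this chain position also matters, with a modest step. No accompanying measurement explains either step.

The compounds shown leave open how an amine, a hydroxy group or a longer ether such as ethoxy would read at the methoxy position. They also leave open whether a propyl chain in place of the ethyl group would raise the number further.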